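Extending the Chain of Compound 1 with Piperidine

The source may report more compounds than this note shows. Statements on the series, on what has been measured and on what is new or still open speak of the compounds shown alone.

Of the compounds shown here, two have so far been measured in a physicochemical assay for acid dissociation, read by spectrophotometry. Compound 1 `CCc1c(O)c(=O)ccn1CC` gives 9.93. Compound 2 `Cc1c(O)c(=O)ccn1CCN(C)C` differs from compound 1 in two places, and in this assay compound 2 gives 9.58. Of these two numbers, compound 1 stands higher, and the gap to compound 2 lies beyond the usual scatter of this kind of measurement.

Compound 3 `CCc1c(O)c(=O)ccn1CCN1CCCCC1` has not yet been measured. It arises from compound 1 by one change: piperidin-1-yl in place of hydrogen on a saturated chain carbon, two bonds along the chain from an aromatic nitrogen. Among the compounds with values here, no measured pair shows this exact step, so its size has to be anticipated rather than read off. Within the data shown here, compound 2 is the only measured compound whose chain carries a second nitrogen, and in this assay compound 2 gives 9.58, the lower of the two numbers. On that basis a small downward step is expected, a number 0.28 log units lower from compound 1 to compound 3 (within the scatter), of a size near the edge of the scatter. For compound 3 the estimate in this assay is 9.65, expected to fall between 9.3 and 10.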

Compound 3, acid dissociation constant: 9.7
Compound 3: the middle estimate sits 0.05 log units below what was measured; the measured number falls inside the stated range.
By their numbers in this assay, from the lowest: compounds 2, 3 and 1 (each within the scatter of the next, the first and the last beyond it).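

Piperidin-1-yl in place of hydrogen on a saturated chain carbon, two bonds along the chain from an aromatic nitrogen, gives in this assay a number 0.23 log units lower from compound 1 to compound 3 (within the scatter) and so adds 6 heavy atoms and a six-membered non-aromatic ring without a step that can be told from the usual scatter. Within the data shown here, this is the first reading for a change in one place at this position, whereas compound 1 and compound 2 differ in two places and could assign nothing to any single change. The numbers show only the size of this step, and nothing available bears on what lies behind it.

From the compounds shown here alone, it remains open whether a different amine, such as morpholine or pyrrolidine, or a carboxylic acid in place of piperidin-1-yl at this carbon would give a step beyond the scatter. Going by these compounds, a shorter or longer chain between the aromatic nitrogen and the piperidine ring is equally open, as is whether the same piperidin-1-yl change would give a step of similar size on the core of compound 2.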